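Reversing a Piperazine-for-Piperidine Swap at the Receptor

A few compounds are considered here, and "the series" means these few. Any claim that something is new, unique, unknown or untested is made for them only; others in the source may bear on it.

Measured in a functional assay on HEK293 cells for agonist activity at Glucose-dependent insulinotropic receptor (Homo sapiens), read by cAMP accumulation, with a stated time of 60 min; a lower number here means that less compound is needed, a higher number that more compound is needed for the effect:
- compound 1, `CCCc1cnc(N2CCC(C3Cc4cc(C5=CCN(S(=O)(=O)CCC)CC5)ccc4O3)CC2)nc1`: 82 nM
- compound 2, `CCCc1cnc(N2CCC(C3Cc4cc(-c5ccc(S(C)(=O)=O)cc5F)ccc4O3)CC2)nc1`: 541 nM
- compound 3, `CCCc1cnc(N2CCC(C3Cc4cc(N5CCN(S(=O)(=O)CCC)CC5)ccc4O3)CC2)nc1`: 544 nM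

Compound 3 stands at the highest number of the three in this assay. Its gap to compound 2 is nil, a 1.0-fold higher number from compound 2 to compound 3 (0.00 log units; within the scatter), while the rise from compound 1 is clear, a 6.6-fold higher number from compound 1 to compound 3 (0.82 log units; beyond the scatter). Compound 4, `CCCc1cnc(N2CCC(C3Cc4cc(C5CCN(S(=O)(=O)CCC)CC5)ccc4O3)CC2)nc1`, differs from compound 3 in one place: 1-(propylsulfonyl)piperidin-4-yl in place of 4-(propylsulfonyl)piperazin-1-yl on an aromatic carbon. The ring that leaves is the one that, when it replaced the ring of compound 1, cost the step of a 6.6-fold higher number from compound 1 to compound 3 (0.82 log units; beyond the scatter); the ring that enters is the same kind as in compound 1, a six-membered non-aromatic ring with one hetero atom carrying the same propylsulfonyl group, but without the ring double bond of compound 1. Within the data shown here, no measured pair isolates that double bond, so the main guide is the step from compound 1 to compound 3, and the step of a 6.6-fold higher number from compound 1 to compound 2 (0.82 log units; beyond the scatter) shows that both other ring replacements were equally costly. The change is therefore expected to roughly undo the rise, an estimated step of a 4.5-fold lower number from compound 3 to compound 4 (0.66 log units; beyond the scatter). Compound 4 is expected to give about 120 nM in this assay, in the range 40 nM to 400 nM.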

Compound 4, half-maximal effective concentration: 386 nM
The estimate for compound 4 lay 3.2-fold (0.51 log units) below the measured number; the measured number falls inside the stated range.
By their numbers in this assay, from the lowest: compound 1; then compounds 4, 2 and 3 (each within the scatter of the next).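

In this assay, putting 1-(propylsulfonyl)piperidin-4-yl in place of 4-(propylsulfonyl)piperazin-1-yl gives a 1.4-fold lower number from compound 3 to compound 4 (0.15 log units; within the scatter), so this exchange of rings alone does not separate the two compounds. The same ring also cannot be told apart from the aromatic 2-fluoro-4-(methylsulfonyl)phenyl group, with a 1.4-fold lower number from compound 2 to compound 4 (0.15 log units; within the scatter), which leaves a saturated ring and an aromatic ring level at this position. Among these compounds, the clearest new information comes from a 4.7-fold higher number from compound 1 to compound 4 (0.67 log units; beyond the scatter), a pair whose only difference is the ring double bond: the earlier compounds could not isolate this feature, and here its absence goes with a step beyond the scatter, showing that the ring's single nitrogen is not enough to keep the low number of compound 1.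

No measurement offered here explains why the double bond matters. Going by these compounds, it also remains open whether its benefit would persist with a different group on the ring nitrogen, such as an acetyl group or a butylsulfonyl chain, in place of the propylsulfonyl group.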